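The source may hold more compounds than are shown below. What is called first, only, known or untested is meant among the compounds shown, and "the series" means these compounds.

Measured so far:
- compound 1, `COc1cccc(CNCCCNc2ccnc3cc(-c4ccc(C(C)(C)C)cc4)ccc23)c1O` — in a physicochemical assay for acid dissociation, compound 1 gives 9.47
- compound 2, `COc1cccc(Oc2ccc3c(NCCCNCc4cccc(OC)c4O)ccnc3c2)c1` — compound 2 gives 9.28
- compound 3, `COc1ccc(Oc2ccc3c(NCCCNCc4cccc(OC)c4O)ccnc3c2)cc1` — compound 3 gives 9.28

Compound 3 sits level with compound 2 at the digits shown, the two together being the lowest of the three numbers; the exchange of one methoxyphenoxy for the other is no change at the digits printed from compound 2 to compound 3 (within the scatter). Against compound 1 the gap is a number 0.19 log units lower from compound 1 to compound 3 (within the scatter), a difference that does not stand out from repeat-measurement noise.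

The next compound, compound 4, `COc1cccc(CNCCCNc2ccnc3cc(Oc4ccc(C(C)(C)C)cc4)ccc23)c1O`, differs from compound 3 in one place: tert-butyl in place of methoxy on an aromatic carbon.

For the measured compounds named here, the steps that bear on this are those in which the group on the shared core was exchanged. Replacing 4-(tert-butyl)phenyl by a methoxyphenoxy gave a number 0.19 log units lower from compound 1 to compound 2 (within the scatter) and a number 0.19 log units lower from compound 1 to compound 3 (within the scatter), and moving the methoxy within the phenoxy gave no change at the digits printed from compound 2 to compound 3 (within the scatter). None of these left the scatter, so a tert-butyl in place of the methoxy on the phenoxy ring is expected to give no step beyond the scatter either, with the number for compound 3 as the anchor.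

For compound 4 the expected step is a number 0.04 log units higher from compound 3 to compound 4 (within the scatter). Compound 4 is therefore estimated at 9.32, with a range from 9.05 to 9.6.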

Compound 4, acid dissociation constant: 9.28
Estimate against measurement, compound 4: 0.04 log units above; the measured number falls inside the stated range.
By their numbers in this assay, from the lowest: compounds 2, 3, 4 and 1 (each within the scatter of the next).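

Working notes: in this assay the exchange of methoxy for tert-butyl on the outer ring, para to a large group, gives no change at the digits printed from compound 3 to compound 4 (within the scatter), and the comparison with the other methoxyphenoxy compound gives no change at the digits printed from compound 2 to compound 4 (within the scatter). So this carbon has now taken a group of 4 heavy atoms with no hydrogen-bond acceptor in place of one of 2 heavy atoms with one, and compound 4 gives 9.28. For the compounds shown here, with the tert-butyl held constant, the oxygen link can also be read on its own, which the earlier steps from compound 1 did not allow since they altered the link and the ring substituent together: 4-(tert-butyl)phenoxy in place of 4-(tert-butyl)phenyl gives a number 0.19 log units lower from compound 1 to compound 4 (within the scatter), and nothing on hand offers an account of these numbers.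

The compounds shown leave open whether an amine or a carboxylic acid at this carbon of the outer ring would give a step beyond the scatter. Also open, on these data alone, is whether a longer chain on the oxygen in place of the aromatic ring would do so.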